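This account rests on a few compounds, and the source may have more. Where it says the series, first, only, none or still open, it means among the compounds named here.

- Compound 1 `Cc1cc(NC(=O)Nc2ccc(Cl)c(Cl)c2)c2ccccc2n1`: 23000 nM
- Compound 2 `Cc1cc(NC(=O)Nc2ccc(Cl)cc2)c2ccccc2n1`: > 25000 nM

In an ADME assay on BJ cells (Homo sapiens) for cytotoxicity, with a stated time of 72 h (on this read-out higher numbers stand for an effect only at larger amounts of compound and lower numbers for an effect already at smaller amounts), compound 2 gives > 25000 nM, which is a limit of the assay and not a number. Compound 3 `Cc1cc(NC(=O)Nc2cccc(Cl)c2)c2ccccc2n1` has the same atoms joined differently, with 3-chlorophenyl in place of 4-chlorophenyl on an amide-type nitrogen. Among the compounds with values here, no measured step shows this kind of change. The nearest evidence is an at least 1.0-fold higher number from compound 1 to compound 2 (0.03 log units; that floor lies within the scatter), and that step removes a chloro rather than moving one, so it bears on the question only indirectly. Since that step stays within the scatter, no step beyond the scatter is expected in this assay here. The expected change is a step that the limit leaves unreadable from compound 2 to compound 3. For compound 3 the estimated value is 27000 nM, with an expected range from 14000 nM to 50000 nM.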

Compound 3, half-maximal effective concentration: > 25000 nM
Compound 3 was reported as a limit; the forecaster's own chance of this, stated with the estimate: 60%; the middle value lies beyond the limit too.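

Compound 2 and compound 3 both end at a limit of the assay and not at a number, so moving the chloro shows no readable change and the step between them cannot be read: the limit of > 25000 nM in this assay, at which 2 of the 3 values shown sit.

What compound 3 adds is that a single chloro in the 3-chlorophenyl form, like the 4-chlorophenyl form, gives no readable value in this assay. The comparison with the dichloro compound gives an at least 1.0-fold higher number from compound 1 to compound 3 (0.03 log units; that floor lies within the scatter), so this is only a floor and shows no separation from compound 1.

Where compound 2 and compound 3 truly lie beyond the limit stays open. So does whether an amine or a carboxylic acid in place of the chloro would give a readable value.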